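Working notes: step from compound 3 to compound 4

A few compounds are considered here, and "the series" means these few. Any claim that something is new, unique, unknown or untested is made for them only; others in the source may bear on it.

Measured so far:
Compound 1 `CCCn1c(NC(=O)c2cc(C)nn2CC)nc2cccc(OC)c21` — in an assay for activation of interferon regulatory factor 3 (Homo sapiens), read by a luciferase reporter, with a stated time of 20 h (a higher number here means that more compound is needed for the effect, a lower number that less compound is needed), compound 1 gives > 100000 nM, a limit of the assay.
Compound 2 `CCCn1c(NC(=O)c2ccc3ccccc3n2)nc2cc(C(N)=O)cc(OC)c21` — in this assay compound 2 gives > 100000 nM, a limit of the assay.
Compound 3 `COc1cc(C(N)=O)cc2nc(NC(=O)c3ccc4ccccc4n3)n(CCCNC(=O)OCc3ccccc3)c12` — in this assay compound 3 gives > 100000 nM, a limit of the assay.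

Every value shown sits at the limit (the limit of > 100000 nM in this assay, at which 3 of the 3 values shown sit). Among the measured compounds shown here, the one step between compounds differing in one place, a step that the two limits leave unreadable from compound 2 to compound 3, is unreadable. Compound 3 thus stands only at a limit, with no number to rank it against the others.

Compound 4 `COc1cc(C(N)=O)cc2nc(NC(=O)c3cccnn3)n(CCCNC(=O)OCc3ccccc3)c12` differs from compound 3 by pyridazin-3-yl in place of quinolin-2-yl on a carbonyl carbon. For the measured compounds named here, no measured step covers this change, and the limits give no direction. Compound 4 is expected to stay at or near the limit, estimated at 150000 nM, range 30000 nM to 1000000 nM. The expected step is a step that the limit leaves unreadable from compound 3 to compound 4, not beyond scatter.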

Compound 4, half-maximal effective concentration: > 100000 nM
Compound 4: only a limit was reported (the forecaster's own chance of this, stated with the estimate: 85%); the middle value lies beyond the limit too.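

No step can be read from compound 3 to compound 4 in this assay, as both stand at the same limit: the limit of > 100000 nM in this assay, at which 4 of the 4 values shown sit.

The compounds shown leave open whether pyridazin-3-yl and quinolin-2-yl differ at all on the carbonyl carbon, and which structure would give a measurable value.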